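The source may report more compounds than this note shows. Statements on the series, on what has been measured and on what is new or still open speak of the compounds shown alone.

Three compounds of the series carry a measured number. Compound 1 `C=C1C(=O)ON(C)C1C(C)C` gives 4160 nM in a functional assay on NALM-6 cells (Homo sapiens) for antiproliferative activity; on this read-out lower numbers stand for stronger inhibition and higher numbers for weaker inhibition. Compound 2 `C=C1C(=O)ON(C)C1c1ccccc1` gives 4960 nM in this assay, the second highest of the three numbers; its nearest neighbour is compound 3 and its furthest is compound 1, and both of those gaps are within the scatter. Compound 3 `C=C1C(=O)ON(C)C1c1ccc(C)cc1` gives 5800 nM in this assay. Among the compounds with values here, the only single-point step among the measured compounds is a 1.2-fold higher number from compound 2 to compound 3 (0.07 log units; within the scatter), which lies within the scatter.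

Compound 4 `C=C1C(=O)ON(C)C1c1ccc(Br)cc1` is not yet measured. Relative to compound 2 it differs as follows: bromo in place of hydrogen on an aromatic carbon. The step that bears on this change is a 1.2-fold higher number from compound 2 to compound 3 (0.07 log units; within the scatter), since there too a single group entered on an aromatic carbon of the same ring in place of hydrogen and the number barely moved. No step beyond the scatter is therefore expected in this assay in either direction. Compound 4 is expected to give 5000 nM in this assay. Its range is estimated from 2500 nM to 10000 nM. This estimate means an expected step of a 1.0-fold higher number from compound 2 to compound 4 (0.00 log units; within the scatter).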

Compound 4, half-maximal inhibitory concentration: 4600 nM
The estimate for compound 4 lay 1.1-fold (0.04 log units) above the measured number; the measured number falls inside the stated range.
By their numbers in this assay, from the lowest: compounds 1, 4, 2 and 3 (each within the scatter of the next).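

In this assay, bromo in place of hydrogen on an aromatic carbon, para to a group of 8 heavy atoms, gives (a 1.1-fold lower number from compound 2 to compound 4 (0.03 log units; within the scatter)), so a halogen now joins methyl as a second group at this position that produces no step beyond the scatter. Bromo in place of methyl at the same place gives (a 1.3-fold lower number from compound 3 to compound 4 (0.10 log units; within the scatter)), so the two groups cannot be told apart on this read-out. No data on the cause accompany these numbers.

On these data alone, whether an amine, a carboxylic acid or a longer chain at this position would produce a step beyond the scatter remains open. Within the data shown here, also open is whether any change elsewhere on the six-membered aromatic ring or in the shared core would do so, as every step so far lies within the scatter.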